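The source may report more compounds than this note shows. Statements on the series, on what has been measured and on what is new or still open speak of the compounds shown alone.

Measured so far in an ADME assay on L929 cells (Mus musculus) for cytotoxicity, read by resazurin assay, with a stated time of 48 h; on this read-out higher numbers stand for lower toxicity in this test and lower numbers for higher toxicity in this test:
- Compound 1 `O=C(O)CCn1c2ccc([N+](=O)[O-])cc2c(=O)n1Cc1ccccc1`: > 256000 nM (a limit)
- Compound 2 `COCCn1c2ccc([N+](=O)[O-])cc2c(=O)n1Cc1ccccc1`: > 256000 nM (a limit)

In this assay compound 2 gives > 256000 nM, which is a limit and not a number. Compound 3 `O=C(c1ccccc1)n1c2ccc([N+](=O)[O-])cc2c(=O)n1Cc1ccccc1` differs from it on an aromatic nitrogen: benzoyl in place of 2-methoxyethyl on an aromatic nitrogen. Among the compounds with values here, the one measured step at that nitrogen is a step that the two limits leave unreadable from compound 1 to compound 2, and the only evidence is the limit of > 256000 nM in this assay, at which 2 of the 2 values shown sit. It gives no size to carry over, so a small downward step in this assay, or none, is expected. The expected step is an at least 1.2-fold lower number from compound 2 to compound 3 (0.10 log units; that floor lies within the scatter). Compound 3 is estimated at 200000 nM, with an expected range from 60000 nM to 400000 nM.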

Compound 3, concentration lethal to 50% of the cells: 146000 nM
The estimate for compound 3 lay 1.4-fold (0.14 log units) above the measured number, within the range that was stated.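

Within the data shown here, with benzoyl on this aromatic nitrogen, compound 3 gives the only reading in this assay here that is not a limit, and the change is an at least 1.7-fold lower number from compound 2 to compound 3 (0.24 log units; that floor lies within the scatter). Against the 2-carboxyethyl group, the same position shows an at least 1.7-fold lower number from compound 1 to compound 3 (0.24 log units; that floor lies within the scatter). Both steps are therefore bounded on one side only, so their full size cannot be read: the limit of > 256000 nM in this assay, at which 2 of the 3 values shown sit.

On these data alone, it remains open whether the aromatic ring or the carbonyl of benzoyl matters for this reading. Also open, as far as these compounds go, is what an amine or a longer chain on this nitrogen would give.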